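Urea in place of aryl amide on the shared core

This account rests on a few compounds, and the source may have more. Where it says the series, first, only, none or still open, it means among the compounds named here.

Measured compounds:
compound 1 `CN(C(=O)c1ccc(F)cc1)c1ccc2[nH]c(-c3n[nH]c4ccccc34)cc2n1`: 9270 nM
compound 2 `CN(c1ccc2[nH]c(-c3n[nH]c4ccccc34)cc2n1)S(=O)(=O)c1ccc(Br)cc1`: 9850 nM

In a functional assay on HCT-116 cells (Homo sapiens) for antiproliferative activity, read by MTT assay, with a stated time of 72 h (on this read-out higher numbers stand for weaker inhibition and lower numbers for stronger inhibition), compound 1 gives 9270 nM and stands with the lower of the two numbers, though the step of a 1.1-fold higher number from compound 1 to compound 2 (0.03 log units; within the scatter) is within the scatter. Compound 3 `COc1ccc(NC(=O)N(C)c2ccc3[nH]c(-c4n[nH]c5ccccc45)cc3n2)cc1` differs from compound 1 by (4-methoxyphenyl)amino in place of 4-fluorophenyl on a carbonyl carbon. Among the compounds with values here, the only measured step bearing on this position, a 1.1-fold higher number from compound 1 to compound 2 (0.03 log units; within the scatter), exchanged the whole aryl amide group for a sulfonyl group without moving the number beyond the scatter. The expected step of a 1.0-fold lower number from compound 1 to compound 3 (0.01 log units; within the scatter) is therefore none beyond the scatter. Compound 3 is estimated at 9000 nM, with a range from 3000 nM to 27000 nM.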

Compound 3, half-maximal inhibitory concentration: 63 nM
The estimate for compound 3 lay 140-fold (2.15 log units) above the measured number, outside the stated range (below it).
By their numbers in this assay, from the lowest: compound 3; then compounds 1 and 2 (each within the scatter of the next).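

In this assay, (4-methoxyphenyl)amino in place of 4-fluorophenyl on a carbonyl carbon gives a 150-fold lower number from compound 1 to compound 3 (2.17 log units; beyond the scatter), so this position can move the number far beyond the scatter, which compounds 1 and 2 had not shown. The step also shows that the amide-type nitrogen and shared core are compatible with a much lower number once this urea is present. Nothing available explains the size of this step.

The compounds shown leave open whether the step belongs to the added amino nitrogen or to the methoxy group. A (4-fluorophenyl)amino group on the same carbonyl carbon would separate these two changes.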